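Mirror Image of Compound 1: Expected Potency

This account rests on a few compounds, and the source may have more. Where it says the series, first, only, none or still open, it means among the compounds named here.

Measured compounds:
compound 1 `O=C(O)c1cccc([C@H]2C[C@@H](c3ccc(OCc4c(-c5c(Cl)cccc5Cl)noc4C4CC4)cc3Cl)C2)c1` gives 92 nM
compound 2 `CCO[C@]1(c2ccc(OCc3c(-c4c(Cl)cccc4Cl)noc3C3CC3)cc2Cl)C[C@H](c2cccc(C(=O)O)c2)C1` gives 220 nM

Both were tested in an assay on HEK293 cells for agonist activity at Bile acid receptor (Homo sapiens); a lower number here means that less compound is needed, a higher number that more compound is needed for the effect. Among the two numbers, compound 1 has the lowest; the only other compound, compound 2, stands higher, and the step of a 2.4-fold higher number from compound 1 to compound 2 (0.38 log units; beyond the scatter) comes from an ethoxy in place of hydrogen on a saturated ring carbon.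

Compound 3 `O=C(O)c1cccc([C@H]2C[C@H](c3ccc(OCc4c(-c5c(Cl)cccc5Cl)noc4C4CC4)cc3Cl)C2)c1` is the mirror image of compound 1: the two compounds have the same atoms and bonds and differ only in configuration as drawn: 2 of 2 stereo elements differ (all stereocentres are inverted: mirror images); a stereocentre at a saturated ring carbon is drawn s in compound 1 and r in compound 3; a stereocentre at a saturated ring carbon is drawn s in compound 1 and r in compound 3. For the measured compounds named here, neither measured step bears on this change; the one step on record, the ethoxy addition, leaves both stereocentres untouched. The shared core of compound 1 carries two stereocentres, and the data give no indication of how inverting both changes the number in this assay. Compound 3 therefore cannot be estimated from an observed step, only from the general experience that a mirror image rarely matches the original exactly.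

Compound 3 is expected to give a higher number than compound 1 in this assay, with the step of a 4.9-fold higher number from compound 1 to compound 3 (0.69 log units; beyond the scatter) carrying wide uncertainty.

Compound 3 is estimated at 450 nM, with a range from 90 nM to 3000 nM.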

Compound 3, half-maximal effective concentration: 15 nM
The estimate for compound 3 lay 30-fold (1.48 log units) above the measured number; measured number below the stated range.
By their numbers in this assay, from the lowest: compound 3; then compound 1; then compound 2.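

Inverting both stereocentres of the shared core gives a 6.1-fold lower number from compound 1 to compound 3 (0.79 log units; beyond the scatter) in this assay, so compound 3, not compound 1, holds the arrangement that needs less compound for the effect. For the compounds shown here, the only earlier step replaced a hydrogen with an ethoxy group and left both stereocentres as they were, so it said nothing about how much the spatial arrangement alone counts at this receptor. This gap can be traced to the arrangement itself, with no change of substituent involved, because nothing else separates the pair: the fact that compounds 1 and 3 differ only in the configuration as drawn.

Both stereocentres change together in this pair, so the compounds shown cannot tell whether one of them accounts for most of the step or both contribute. Going by these compounds, it also remains open whether the ethoxy step seen on the arrangement of compound 1 would carry over to the arrangement of compound 3, and how a smaller group such as methoxy or hydroxyl in place of that hydrogen would fare on either arrangement.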